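Swapping a dimethylphenyl for a methylsulfanylphenyl on the core

This account rests on a few compounds, and the source may have more. Where it says the series, first, only, none or still open, it means among the compounds named here.

Of the compounds shown here, three have been measured in a functional assay on SW-620 cells (Homo sapiens) for cytotoxicity; on this read-out lower numbers stand for stronger inhibition of growth and higher numbers for weaker inhibition of growth. Compound 1 `COc1ccc(C2=C(c3ccc(SC)cc3)CC3CCCN3C2=O)cc1OC(=O)C1CCCN1C(=O)OC(C)(C)C` gives 10000 nM in this assay. Compound 2 `CSc1ccc(C2=C(c3ccc(F)c(F)c3)C(=O)N3CCCC3C2)cc1` gives 200 nM, and compound 3 `CSc1ccc(C2=C(c3ccc(C)c(C)c3)C(=O)N3CCCC3C2)cc1` gives 700 nM. Compound 3 thus stands second highest of the three numbers, with compound 2 nearest at the lower end and compound 1 furthest at the higher end. For the measured compounds named here, the only step between measured compounds that differ in one place is a 3.5-fold higher number from compound 2 to compound 3 (0.54 log units; beyond the scatter).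

Compound 4 `CSc1ccc(C2=C(c3ccc(SC)cc3)C(=O)N3CCCC3C2)cc1` is not yet measured. It differs from compound 3 by 4-(methylsulfanyl)phenyl in place of 3,4-dimethylphenyl on a double-bonded ring carbon. Going by the values given here, no measured step bears directly on this change: the step of a 3.5-fold higher number from compound 2 to compound 3 (0.54 log units; beyond the scatter) concerns a different pair of groups on the same double-bonded ring carbon, and it shows that exchanging the substituents there can move the number beyond the scatter. Among the compounds with values here, the exchange of dimethylphenyl for methylsulfanylphenyl has no measured precedent here, so compound 4 is expected to land near compound 3, the estimated step being a 1.4-fold lower number from compound 3 to compound 4 (0.15 log units; within the scatter). Compound 4 is therefore estimated at 500 nM, within a range from 150 nM to 2000 nM.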

Compound 4, concentration for 50% growth inhibition: 7000 nM
Beside the measured number, compound 4's estimate is 14-fold (1.15 log units) below it, outside the stated range (above it).
By their numbers in this assay, from the lowest: compound 2; then compound 3; then compounds 4 and 1 (each within the scatter of the next).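

In this assay, for the compounds shown here, the double-bonded ring carbon proves less forgiving than the single earlier step could show: 4-(methylsulfanyl)phenyl in place of 3,4-dimethylphenyl gives a 10-fold higher number from compound 3 to compound 4 (1.00 log units; beyond the scatter), although the two groups have the same number of heavy atoms. Set against 3,4-difluorophenyl, the same entering group gives a 35-fold higher number from compound 2 to compound 4 (1.54 log units; beyond the scatter), so the choice of phenyl group at this carbon alone moves the number by a large margin on the shared core. Nothing at hand explains this change.

The compounds shown leave open whether the shift is tied to the entering sulfur or to the departing pair of methyl groups. They also leave open how a phenyl group carrying an amine or a carboxylic acid would read at this carbon.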